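The compounds below may be only part of what the source reports. "The series", "measured", "known", "first", "only" and "open" are said of these compounds alone.

Compound 1, whose structure is `COc1cc(-c2cc(/C=C/C(=O)c3ccc(N)cc3)[nH]n2)cc(OC)c1OC`, sits at the edge of what the measurements can show. In a functional assay on IGROV-1 cells (Homo sapiens) for inhibition, read by sulforhodamine B assay, with a stated time of 48 h (a higher number here means that more compound is tolerated, a lower number that less compound is tolerated), compound 1 gives > 100000 nM, which is a limit of the assay and not a number. Compound 2, with the structure `COc1cc(-c2cc(/C=C/C(=O)c3ccc(Cl)c(Cl)c3)[nH]n2)cc(OC)c1OC`, gives > 100000 nM in this assay, again a limit. The step that the two limits leave unreadable from compound 1 to compound 2 is therefore unreadable, and the only firm point is the limit of > 100000 nM in this assay, at which 2 of the 2 values shown sit.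

Compound 3, with the structure `COc1ccc(-c2cc(/C=C/C(=O)c3ccc(N)cc3)[nH]n2)cc1OC`, differs from compound 1 by hydrogen in place of methoxy on an aromatic carbon. Within the data shown here, no measured step touches this change, since the one step recorded concerns the group on the carbonyl carbon, not the methoxy groups, and it was unreadable anyway. With compound 1 already at the limit, compound 3 is expected to stay near it as well, so the step of a number no higher from compound 1 to compound 3 (the limit leaves the size open) is an estimate carrying no direction that the data could support. Compound 3 is estimated at 100000 nM, within 30000 nM to 300000 nM.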

Compound 3, concentration lethal to 50% of the cells: 73000 nM
Compound 3: the middle estimate sits 1.4-fold (0.14 log units) above what was measured; the range from low to high includes it.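

Hydrogen in place of methoxy on this aromatic carbon brings the series off the ceiling of this assay, giving an at least 1.3-fold lower number from compound 1 to compound 3 (0.13 log units; that floor lies within the scatter). Compound 3 therefore gives the only readable number among the compounds shown, so this position is the first place where a change can be tied to a value, though the printed floor alone does not separate the two compounds beyond the usual scatter. The true size of the step stays open, and the other values remain limits of the assay and not numbers: the limit of > 100000 nM in this assay, at which 2 of the 3 values shown sit.

Going by these compounds, it remains open whether a hydroxy group, an ethoxy group or a fluorine atom at this place would give a readable number. On these data alone, it is equally open whether hydrogen in place of methoxy would do so alongside the 3,4-dichlorophenyl group of compound 2.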